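From 1H-pyrazol-1-yl to 1H-tetrazol-1-yl on a shared core

The source may report more compounds than this note shows. Statements on the series, on what has been measured and on what is new or still open speak of the compounds shown alone.

In a functional assay on HUVEC cells (Homo sapiens), read by scintillation counting and thymidine incorporation, with a stated time of 24 h (a higher number here means a weaker inhibitor, a lower number a stronger inhibitor), compound 1 `CCC(C)n1ncn(-c2ccc(N3CCN(c4ccc(OC[C@@H]5CO[C@@](Cn6cc(C)nc6C)(c6ccc(Cl)cc6Cl)O5)cc4)CC3)cc2)c1=O` gives 492 nM and compound 2 `CCC(C)n1ncn(-c2ccc(N3CCN(c4ccc(OC[C@@H]5CO[C@@](Cn6cccn6)(c6ccc(Cl)cc6Cl)O5)cc4)CC3)cc2)c1=O` gives 307 nM. Among the measured compounds shown here, these are the only two numbers available, and the gap between them is a 1.6-fold lower number from compound 1 to compound 2 (0.20 log units; within the scatter). Compound 2 therefore cannot be separated from compound 1 on these measurements.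

Compound 3 `CCC(C)n1ncn(-c2ccc(N3CCN(c4ccc(OC[C@@H]5CO[C@@](Cn6cnnn6)(c6ccc(Cl)cc6Cl)O5)cc4)CC3)cc2)c1=O` has not yet been measured. It differs from compound 2 by one group, (1H-tetrazol-1-yl in place of 1H-pyrazol-1-yl on a saturated chain carbon bound to a saturated ring carbon), with 1H-tetrazol-1-yl in place of 1H-pyrazol-1-yl on a saturated chain carbon bound to a saturated ring carbon.

For the measured compounds named here, only one measured step bears on this change: the exchange at the same place of 2,4-dimethyl-1H-imidazol-1-yl for 1H-pyrazol-1-yl, which gave a 1.6-fold lower number from compound 1 to compound 2 (0.20 log units; within the scatter). Going by the values given here, that is a single step, and no compound with 1H-tetrazol-1-yl has a number yet, so the guide is thin and the range must stay wide. No shift beyond the scatter is expected in this assay, and no direction can be favoured with confidence. The expected change is a 1.1-fold higher number from compound 2 to compound 3 (0.06 log units; within the scatter). For compound 3 the estimate is 350 nM, with an expected range from 130 nM to 950 nM.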

Compound 3, half-maximal inhibitory concentration: 73 nM
For compound 3 the middle estimate is 4.8-fold (0.68 log units) above the measured one; the whole stated range lies above it.
By their numbers in this assay, from the lowest: compound 3; then compounds 2 and 1 (each within the scatter of the next).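

In this assay this position, on a saturated chain carbon bound to a saturated ring carbon, now gives a shift beyond the scatter: 1H-tetrazol-1-yl in place of 1H-pyrazol-1-yl brings a 4.2-fold lower number from compound 2 to compound 3 (0.62 log units; beyond the scatter) and so separates two groups where the earlier pair could not be told apart. Set against 2,4-dimethyl-1H-imidazol-1-yl, the same group brings a 6.7-fold lower number from compound 1 to compound 3 (0.83 log units; beyond the scatter), which makes compound 3 the strongest inhibitor of the three, since its steps to both others lie beyond the scatter. The change from 1H-pyrazol-1-yl keeps the heavy-atom count and the lack of net charge and alters the ring's make-up, with nitrogen taking the place of carbon, but nothing available here accounts for the lower number.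

The compounds shown leave open whether a 1H-1,2,4-triazol-1-yl or a 2H-tetrazol-2-yl group at this position would match 1H-tetrazol-1-yl, and whether a methyl group on the tetrazole ring would keep the number this low. They also leave open whether the same exchange would give a step of this size on a core carrying a different chain in place of the sec-butyl group.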